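A few compounds are considered here, and "the series" means these few. Any claim that something is new, unique, unknown or untested is made for them only; others in the source may bear on it.

In a functional assay on MCF7 cells (Homo sapiens) for antiproliferative activity, read by MTT assay, with a stated time of 48 h (on this read-out higher numbers stand for weaker inhibition and lower numbers for stronger inhibition), compound 1 `COc1cc(/C=C/C(=O)N2Cc3ccccc3[C@@H](OCc3ccccc3)[C@@H]2CO)ccc1O` gives 37300 nM and compound 2 `Cc1ccc(S(=O)(=O)NCC(=O)N2Cc3ccccc3[C@@H](OCc3ccccc3)[C@@H]2CO)cc1` gives 11500 nM. Compound 2 thus has the lower of the two numbers, meaning stronger inhibition, and the gap lies beyond the usual scatter. The next structure, compound 3 `Cc1ccc(S(=O)(=O)N[C@H](C(=O)N2Cc3ccccc3[C@@H](OCc3ccccc3)[C@@H]2CO)C(C)C)cc1`, makes one change to compound 2: isopropyl in place of hydrogen on a saturated chain carbon bound to a carbonyl carbon and a sulfonamide nitrogen, with isopropyl in place of hydrogen on a saturated chain carbon bound to a carbonyl carbon and a sulfonamide nitrogen. Within the data shown here, no measured pair shows a change in one place, so no step beyond the scatter is expected in this assay. The expected change is a 1.3-fold lower number from compound 2 to compound 3 (0.11 log units; within the scatter). The estimate for compound 3 is 9000 nM, with an expected range of 3500 nM to 25000 nM.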

Compound 3, half-maximal inhibitory concentration: 60400 nM
Beside the measured number, compound 3's estimate is 6.7-fold (0.83 log units) below it; measured number outside the range, above it.
By their numbers in this assay, from the lowest: compound 2; then compounds 1 and 3 (each within the scatter of the next).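

In this assay, placing isopropyl in place of hydrogen on this saturated chain carbon gives a 5.3-fold higher number from compound 2 to compound 3 (0.72 log units; beyond the scatter) and so weaker inhibition. Among these compounds, this is the first change in one place that can be read, and it shows that inhibition responds to what this carbon carries. No measured evidence explains the step.

One substituent cannot show whether the loss grows with size, so a methyl at this carbon would be informative. On these data alone, it also remains open how an amine or a carboxylic acid there would behave.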